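Isopropyl for Methyl on the Shared Core

This account rests on a few compounds, and the source may have more. Where it says the series, first, only, none or still open, it means among the compounds named here.

Compound 1, `Cn1cc2c(Cl)nc(NC(=O)c3ccccc3)nc2n1`: > 100000 nM, a limit of the assay
Compound 2, `CC(C)n1cc2c(Cl)nc(NC(=O)c3ccccc3)nc2n1`: 19600 nM
Compound 3, `Cn1cc2c(Cl)nc(N)nc2n1`: 29700 nM

In an assay on CHO cells for displacement of a labelled ligand from adenosine receptor A1 (Homo sapiens), read by scintillation counting, with a stated time of 3 h (on this read-out lower numbers stand for stronger inhibition and higher numbers for weaker inhibition), compound 1 gives > 100000 nM, which is a limit of the assay and not a number, as shown by the limit of > 100000 nM in this assay, at which 1 of the 3 values shown sits. Compound 2 gives 19600 nM in this assay. Among the compounds with values here, the single change between them, (isopropyl in place of methyl on an aromatic nitrogen), produced an at least 5.1-fold lower number from compound 1 to compound 2 (0.70 log units; beyond the scatter). Compound 3 gives 29700 nM in this assay; compound 3 and compound 1 differ in more than one place, and the difference between the two cores is not broken down here.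

Compound 4, `CC(C)n1cc2c(Cl)nc(N)nc2n1`, has not yet been measured. It arises from compound 3 by the same change, (isopropyl in place of methyl on an aromatic nitrogen), at a place described in exactly the same words as before. Given that the earlier step was an at least 5.1-fold lower number from compound 1 to compound 2 (0.70 log units; beyond the scatter), the step from compound 3 to compound 4 is expected to be of similar size and direction, a 5.9-fold lower number from compound 3 to compound 4 (0.77 log units; beyond the scatter), though one pair is thin ground for a rule. Compound 4 is therefore estimated to give 5000 nM in this assay, within a range from 1500 nM to 15000 nM.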

Compound 4, inhibition constant: 9000 nM
Estimate against measurement, compound 4: 1.8-fold (0.26 log units) below; measured number inside the range.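

In this assay, putting isopropyl in place of methyl on an aromatic nitrogen gives a lower number on the second core as well, with a 3.3-fold lower number from compound 3 to compound 4 (0.52 log units; beyond the scatter). Compound 1 gives > 100000 nM, which is a limit of the assay and not a number. The two pairs therefore agree in direction, but two pairs make no general rule, and they do not show that the size of the step carries over from one core to the other: the same change on two cores in this assay, an at least 5.1-fold lower number (0.70 log units; beyond the scatter) from compound 1 to compound 2 and a 3.3-fold lower number (0.52 log units; beyond the scatter) from compound 3 to compound 4; the limit leaves it open whether they differ

The compounds shown carry only methyl or isopropyl on that aromatic nitrogen, so it remains open how an ethyl, a cyclopropyl or a longer chain there would compare. On these data alone, it is also open whether the step would recur on a third core, for example one with an acetamide in place of the amino group of compound 3.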